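The source may report more compounds than this note shows. Statements on the series, on what has been measured and on what is new or still open speak of the compounds shown alone.

Among the compounds with values here, compound 2 `CCCCCCCCCCCCCCCCCCNC(=O)[C@H]1CSC(c2ccc([N+](=O)[O-])cc2)N1` is the weaker of the two compounds measured so far in a functional assay on TSU-Pr1 cells for antiproliferative activity against TSU (Homo sapiens), read by sulforhodamine B assay; on this read-out higher numbers stand for weaker inhibition and lower numbers for stronger inhibition: compound 2 gives 15900 nM, while compound 1 `CCCCCCCCCCCCCCCCCCNC(=O)[C@H]1CSC(c2c[nH]c3ccccc23)N1` gives 4400 nM. The two share a core and differ only in the group on a saturated ring carbon, and that single swap produced a 3.6-fold higher number from compound 1 to compound 2 (0.56 log units; beyond the scatter), a change clearly beyond the scatter. Compound 3 `CCCCCCCCCCCCCCCCCCNC(=O)[C@H]1CSC(c2c(Cl)cccc2Cl)N1` keeps everything else the same and alters that same position again: 2,6-dichlorophenyl in place of 4-nitrophenyl on a saturated ring carbon. Within the data shown here, only one measured step bears on this change, the step from compound 1 to compound 2, and it shows that exchanging the group at this position shifts the number by a modest amount. Neither a halogenated ring nor this substitution pattern has been measured here, so the direction of the move is not settled by the data. The estimate is therefore a modest step in a 2.0-fold lower number from compound 2 to compound 3 (0.30 log units; within the scatter), with a wide range on either side. Compound 3 is expected to give 8000 nM, with a likely range from 2500 nM to 25000 nM in this assay.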

Compound 3, half-maximal inhibitory concentration: 20000 nM
The estimate for compound 3 lay 2.5-fold (0.40 log units) below the measured number, within the range that was stated.
By their numbers in this assay, from the lowest: compound 1; then compounds 2 and 3 (each within the scatter of the next).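

In this assay the swap of 4-nitrophenyl for 2,6-dichlorophenyl on this saturated ring carbon gives a 1.3-fold higher number from compound 2 to compound 3 (0.10 log units; within the scatter) and so does not separate the two groups, even though the entering group has 0 hydrogen-bond acceptors where the leaving group has 2. Set against the 1H-indol-3-yl group of compound 1, the same 2,6-dichlorophenyl group gives a 4.5-fold higher number from compound 1 to compound 3 (0.66 log units; beyond the scatter) and confirms with a second step what had rested on one: compound 1 stands apart from both phenyl-bearing compounds, which sit together at the higher numbers. No measurement at hand says why compound 1 differs from the other two.

The compounds shown leave open whether a plain phenyl group or a 4-aminophenyl group at this carbon would fall with compound 2 and compound 3 or with compound 1. Also open, on these data alone, is whether the gap between compound 1 and the other two would hold with a shorter chain on the amide nitrogen in place of the long one that all three carry.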